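Shrinking the ring on the thiocarbonyl amine

The compounds below may be only part of what the source reports. "The series", "measured", "known", "first", "only" and "open" are said of these compounds alone.

Compound 1 `CCOC(=O)c1cc(=O)c2cc(CSC(=S)N(C)c3ccccc3)ccc2o1`: 18100 nM
Compound 2 `O=c1cc(CSC(=S)N2CCCCC2)oc2ccccc12`: > 25000 nM
Compound 3 `O=c1c(Cl)c(CSC(=S)N2CCCCC2)oc2ccccc12`: 9800 nM

In a functional assay on HeLa cells (Homo sapiens) for antiproliferative activity, read by MTT assay, with a stated time of 72 h (on this read-out lower numbers stand for stronger inhibition and higher numbers for weaker inhibition), compound 3 gives 9800 nM, and compound 1 sits within the usual scatter of that number with 18100 nM. For compound 2 this assay reports only a limit, > 25000 nM (the limit of > 25000 nM in this assay, at which 1 of the 3 values shown sits). For the measured compounds named here, the one measured step, an at least 2.5-fold lower number from compound 2 to compound 3 (0.40 log units; beyond the scatter), concerns a different site than the change to compound 4 `O=c1c(Cl)c(CSC(=S)N2CCCC2)oc2ccccc12`, which is pyrrolidin-1-yl in place of piperidin-1-yl on a thiocarbonyl carbon. Going by the values given here, no measured pair speaks to this ring change, so no step beyond the scatter is expected, with the value of compound 4 estimated at 10000 nM (range 4000 nM to 25000 nM), a step of a 1.0-fold higher number from compound 3 to compound 4 (0.01 log units; within the scatter) from compound 3.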

Compound 4, half-maximal inhibitory concentration: 700 nM
For compound 4 the middle estimate is 14-fold (1.15 log units) above the measured one; the whole stated range lies above it.
By their numbers in this assay, from the lowest: compound 4; then compounds 3 and 1 (each within the scatter of the next). At a limit, above all of these: compound 2.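

In this assay, pyrrolidin-1-yl in place of piperidin-1-yl on the thiocarbonyl carbon gives a 14-fold lower number from compound 3 to compound 4 (1.15 log units; beyond the scatter), so the amine ring at this position strongly affects the read-out. For the compounds shown here, the earlier compounds could not show this, as their only measured step concerned a chloro group at a different site. Nothing measured here explains why the smaller ring has this effect.

As far as these compounds go, it remains open whether the pyrrolidin-1-yl gain would persist without the chloro group. It is also unknown how a morpholine ring or a dimethylamino group would behave at the same place.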